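The source may report more compounds than this note shows. Statements on the series, on what has been measured and on what is new or still open speak of the compounds shown alone.

Working notes on the series. Compound 2 `Fc1ccccc1/C=C/c1ccc(Cl)cc1` is the reference for this step. In an assay on HepG2 cells for activation of nuclear factor erythroid 2-related factor 2 (Homo sapiens), read by a luciferase reporter, with a stated time of 5 h (on this read-out lower numbers stand for an effect already at smaller amounts and higher numbers for an effect only at larger amounts of compound), compound 2 gives 1600 nM, the lowest of the two numbers obtained so far. The nearest is compound 1 `COc1cccc(/C=C/c2ccccc2F)c1`; in this assay compound 1 gives 3800 nM, a gap from compound 2 that lies beyond the usual scatter. Compound 3 `COc1ccc(/C=C/c2ccc(F)c(F)c2)cc1` returns only a limit of the assay: in this assay compound 3 gives > 15000 nM. That entry is the limit of > 15000 nM in this assay, at which 1 of the 3 values shown sits, and is not a number.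

Compound 4 `Fc1ccc(/C=C/c2ccccc2F)cc1` has not been measured in this assay. Against compound 2 the change is fluoro in place of chloro on an aromatic carbon, the rest of the shared core being unchanged. Among the compounds with values here, no two compounds already measured differ in this place alone, so nothing sets the size of this step directly. The expectation is a small move toward a higher number in this assay, most likely within the scatter of repeated measurements, given as a 1.6-fold higher number from compound 2 to compound 4 (0.19 log units; within the scatter). Compound 4 is therefore estimated at 2500 nM in this assay, with a range from 1000 nM to 6500 nM.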

Compound 4, half-maximal effective concentration: 3600 nM
Beside the measured number, compound 4's estimate is 1.4-fold (0.16 log units) below it; measured number inside the range.
By their numbers in this assay, from the lowest: compound 2; then compounds 4 and 1 (each within the scatter of the next). At a limit, above all of these: compound 3.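

In this assay the series now has its first step at a single place, a 2.3-fold higher number from compound 2 to compound 4 (0.35 log units; beyond the scatter) for fluoro in place of chloro on an aromatic carbon. This position is therefore not indifferent to the exchange: one heavy atom replaces another, no ring, hydrogen-bond donor, hydrogen-bond acceptor or net charge enters or leaves, and the step still lies beyond the scatter, though it remains modest. Nothing measured for these compounds gives a cause for this step.

With only chloro and fluoro compared at this position, the compounds shown leave open where a bromo, a methyl, a nitrile or an amine would stand there, and whether any order seen for these two groups extends to others. They also leave open whether the same exchange at another place on the shared core, or on a core carrying other groups, would give a step of similar size, as only this one pair of the compounds shown differs by this change alone.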